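Amine replacements on the shared core: compound 4

A few compounds are considered here, and "the series" means these few. Any claim that something is new, unique, unknown or untested is made for them only; others in the source may bear on it.

Measured so far:
compound 1 `CCCCCCCCNc1nc(SCc2ccc(C(F)(F)F)cc2)nc2ccccc12`: 13400 nM
compound 2 `FC(F)(F)c1ccc(CSc2nc(N3CCCCC3)c3ccccc3n2)cc1`: > 50000 nM (a limit of the assay)
compound 3 `FC(F)(F)c1ccc(CSc2nc(Nc3ccccc3Cl)c3ccccc3n2)cc1`: > 50000 nM (a limit of the assay)

Going by the values given here, in a functional assay on HGC-27 cells (Homo sapiens) for cytotoxicity, read by MTT assay, with a stated time of 72 h (on this read-out higher numbers stand for weaker inhibition and lower numbers for stronger inhibition), compound 1 gives 13400 nM, the only number among the three. For compound 2 the assay returns only a limit, > 50000 nM. For compound 3 the assay likewise returns only a limit, > 50000 nM. Both measured steps away from compound 1 run the same way: an at least 3.7-fold higher number from compound 1 to compound 2 (0.57 log units; beyond the scatter), and an at least 3.7-fold higher number from compound 1 to compound 3 (0.57 log units; beyond the scatter). Their true size is hidden because of the limit of > 50000 nM in this assay, at which 2 of the 3 values shown sit.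

Compound 4 is `Cc1ccccc1Nc1nc(SCc2ccc(C(F)(F)F)cc2)nc2ccccc12`. Against compound 1 the change is 2-methylphenyl in place of octyl on a nitrogen on an aromatic ring. Among the compounds with values here, the step that bears on it most directly is the one to compound 3, since there too an aryl ring took the place of the octyl chain on the same nitrogen, and that step read an at least 3.7-fold higher number from compound 1 to compound 3 (0.57 log units; beyond the scatter). The 2-methylphenyl group of compound 4 stands close to the 2-chlorophenyl of compound 3, so a step of similar direction is expected in this assay, most likely ending at the limit again. The expected step is a 3.7-fold higher number from compound 1 to compound 4 (0.57 log units; beyond the scatter). Compound 4 is therefore estimated at 50000 nM, in the range 15000 nM to 160000 nM.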

Compound 4, half-maximal inhibitory concentration: 27500 nM
Beside the measured number, compound 4's estimate is 1.8-fold (0.26 log units) above it, within the range that was stated.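

In this assay, 2-methylphenyl in place of octyl on the nitrogen gives a 2.1-fold higher number from compound 1 to compound 4 (0.31 log units; beyond the scatter), so an aryl ring on this nitrogen is not tied to the limit, as compound 3 alone might have suggested. Methyl in place of chloro on an aromatic carbon gives an at least 1.8-fold lower number from compound 3 to compound 4 (0.25 log units; that floor lies within the scatter), and swapping the piperidin-1-yl group for the aryl amine gives an at least 1.8-fold lower number from compound 2 to compound 4 (0.25 log units; that floor lies within the scatter). Both of these steps are only floors, and neither can be read as a firm separation of compound 4 from the other two because their true size is hidden by the assay limit: the limit of > 50000 nM in this assay, at which 2 of the 4 values shown sit.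

Open, as far as these compounds go, is whether a plain phenyl, or a methoxy group in place of the methyl on the same ring, keeps a readable number in this assay. Also open, from the compounds shown here alone, is how the number responds on the same aromatic carbon to a chain longer or shorter than octyl, such as decylamino or butylamino, or to a ring amine such as morpholine in place of piperidin-1-yl.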